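The source may report more compounds than this note shows. Statements on the series, on what has been measured and on what is new or still open speak of the compounds shown alone.

Measured compounds:
- compound 1, `Oc1ccc(CNc2cc(Br)cc3[nH]ncc23)c(F)c1` — "not active" (no number reported) in an assay for inhibition of Tryptophan 2,3-dioxygenase (Homo sapiens), with a stated time of 1 h, tested at 10 uM; on this read-out higher numbers stand for more inhibition at the one concentration tested (going by the name of the read-out) and lower numbers for less inhibition
- compound 2, `Brc1cc(NCc2ccco2)c2cn[nH]c2c1` — 64%

Going by the values given here, compound 2 is the only compound here with a number in this assay; compound 1 is reported without one. Compound 3, `Nc1nc(CNc2cc(Br)cc3[nH]ncc23)cs1`, differs from compound 2 by 2-amino-1,3-thiazol-4-yl in place of furan-2-yl on a saturated chain carbon bound to a nitrogen on an aromatic ring. Among the compounds with values here, no measured pair shows this change, so its effect is unknown. Since compound 2 gives 64%, a step of modest size in this assay is expected, with a downward direction thought somewhat more likely than none. Compound 3 is estimated at 50%, within 15% to 85%, a step of a number 14 percentage points lower from compound 2 to compound 3 (beyond the scatter).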

Compound 3, a percentage reported as inhibition, at one concentration (the size of the read-out at that concentration, not a potency): 73%
Compound 3: middle estimate off by 23 percentage points, on the low side; low and high end bracket the measured number.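

In this assay, going from furan-2-yl to 2-amino-1,3-thiazol-4-yl on the saturated chain carbon bound to a nitrogen on an aromatic ring gives a number 9 percentage points higher from compound 2 to compound 3 (within the scatter) and so separates the two groups by no more than the usual scatter. This place therefore holds a second five-membered aromatic ring, one with more hetero atoms and a hydrogen-bond donor, while the read-out stays numerically measurable. Nothing available bears on the reason for this result. Left open is what the amino group of compound 3 contributes, which a plain 1,3-thiazol-4-yl would show. A longer chain between the ring and the nitrogen also remains untested among the compounds shown.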